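A few compounds are considered here, and "the series" means these few. Any claim that something is new, unique, unknown or untested is made for them only; others in the source may bear on it.

In a functional assay on MV4-11 cells (Homo sapiens) for antiproliferative activity, with a stated time of 6 days, tested at 1.56 uM (on this read-out lower numbers stand for a weaker effect and higher numbers for a stronger effect at the one concentration tested), compound 2 `CNC(=O)N1CCCc2ccc(NC(=O)c3cccc(-c4cnn(C(C)=O)c4)c3)cc21` gives 33.6%. Among the measured compounds shown here, on the numbers measured so far it stands alongside its only neighbour, compound 1 `CNC(=O)N1CCCc2ccc(NC(=O)c3cccc(-c4cn[nH]c4)c3)cc21`, which in this assay gives 27.9%; the single step recorded, a number 5.7 percentage points higher from compound 1 to compound 2 (within the scatter), lies within the scatter, so the two compounds cannot be told apart on this read-out. Compound 3 `CNC(=O)N1CCCc2ccc(NC(=O)c3cccc(-c4ccn(C(C)=O)n4)c3)cc21` has the same atoms as compound 2 joined differently: 1-acetyl-1H-pyrazol-3-yl in place of 1-acetyl-1H-pyrazol-4-yl on an aromatic carbon. For the measured compounds named here, no measured step bears on moving the point of attachment of the acetylpyrazole; the one step available, acetyl in place of hydrogen on an aromatic nitrogen, produced no change beyond the scatter. With nothing pointing in either direction, the expected step is a number 2.6 percentage points lower from compound 2 to compound 3 (within the scatter), that is, none beyond the scatter. Compound 3 is therefore estimated to give 31% in this assay, with a range from 16% to 46%.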

Compound 3, a percentage reported as inhibition, at one concentration (the size of the read-out at that concentration, not a potency): 27.6%
Compound 3: the middle estimate sits 3.4 percentage points above what was measured; measured number inside the range.
By their numbers in this assay, from the lowest: compounds 3, 1 and 2 (each within the scatter of the next).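

Moving the attachment of the acetylpyrazole on the six-membered aromatic ring, with 1-acetyl-1H-pyrazol-3-yl in place of 1-acetyl-1H-pyrazol-4-yl, gives in this assay a number 6 percentage points lower from compound 2 to compound 3 (within the scatter) and is the first test of this change. Taking 1-acetyl-1H-pyrazol-3-yl in place of 1H-pyrazol-4-yl, which alters both the attachment and the ring nitrogen substituent, gives a number 0.3 percentage points lower from compound 1 to compound 3 (within the scatter) and likewise separates nothing, so compounds 1, 2 and 3 cannot be told apart on this read-out. No measurement at hand offers an explanation of these results.

On these data alone, whether an amine or a carboxylic acid in place of the pyrazole at this carbon would shift the number beyond the scatter stays open. So does the effect of a longer acyl chain than acetyl on the pyrazole nitrogen.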